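The source may report more compounds than this note shows. Statements on the series, on what has been measured and on what is new or still open speak of the compounds shown alone.

Compound 1 `N#Cc1ccc(N2CCCc3c(-c4cccnc4)cccc32)cc1C(F)(F)F` gives 12300 nM in a functional assay on CWR22R cells (Homo sapiens) for antiproliferative activity, read by CCK-8 assay, with a stated time of 6 days; on this read-out higher numbers stand for weaker inhibition and lower numbers for stronger inhibition.
Compound 2 `CCN(c1ccc(C#N)c(Cl)c1)c1cc(-c2cccs2)ccc1C` gives 22000 nM in this assay.
Compound 3 `CCN(c1ccc(C#N)c(Cl)c1)c1cc(-c2ccccc2)ccc1C` reaches only a limit of this assay, > 30000 nM.

Among the compounds with values here, compound 1 and compound 2 lie within the usual scatter of each other, and the remaining value, that of compound 3, is a limit (the limit of > 30000 nM in this assay, at which 1 of the 3 values shown sits), so no compound can be called the most active here.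

Compound 4 `Cn1nccc1-c1cccc2c1CCCN2c1ccc(C#N)c(C(F)(F)F)c1` has not yet been measured. It differs from compound 1 in one place (1-methyl-1H-pyrazol-5-yl in place of pyridin-3-yl on an aromatic carbon). Within the data shown here, the only measured step that resembles it, one aryl ring replaced by another on an aromatic carbon, is an at least 1.3-fold higher number from compound 2 to compound 3 (0.13 log units; that floor lies within the scatter), a change that stayed within the scatter and on a different core. That gives no ground to expect a step beyond the scatter from compound 1 to compound 4 in this assay, in either direction.

Compound 4 is therefore expected to give about 12000 nM, between 5000 nM and 30000 nM. The step of a 1.0-fold lower number from compound 1 to compound 4 (0.01 log units; within the scatter) that this estimate means is expected to lie within the scatter.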

Compound 4, half-maximal inhibitory concentration: 10400 nM
Beside the measured number, compound 4's estimate is 1.2-fold (0.06 log units) above it; the measured number falls inside the stated range.
By their numbers in this assay, from the lowest: compounds 4, 1 and 2 (each within the scatter of the next, the first and the last beyond it). At a limit, above all of these: compound 3.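

In this assay the change to 1-methyl-1H-pyrazol-5-yl from pyridin-3-yl gives a 1.2-fold lower number from compound 1 to compound 4 (0.07 log units; within the scatter) and so shows that, on this aromatic carbon, a five-membered aromatic ring with 2 hetero atoms and a six-membered aromatic ring with 1 hetero atom cannot be told apart by this read-out. The earlier ring swap was on a different core and ended at a limit, whereas here both ends are real numbers on one shared core, so the step can be read in full. Nothing measured here bears on what lies behind this result.

Going by these compounds, it remains open whether a group of another kind on this carbon, such as an amine, a carboxylic acid or a longer alkyl chain, would move the number beyond the scatter. On these data alone, it also remains open whether the same ring swap would stay within the scatter on the core of compound 2.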